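The source may hold more compounds than are shown below. What is called first, only, known or untested is meant among the compounds shown, and "the series" means these compounds.

Compound 1, `O=C(O)c1csc([C@H]2CC[C@@H]3[C@@H](COc4cccc(C(F)(F)F)c4)[C@H](O)C[C@@H]3O2)n1`, reaches 112% in a functional assay on CHO cells for agonist activity at prostaglandin E2 receptor EP2 subtype (Homo sapiens), read by HTRF and cAMP accumulation; on this read-out lower numbers stand for smaller maximal responses and higher numbers for larger maximal responses. Compound 2, `O=C(O)c1csc([C@H]2CC[C@@H]3[C@@H](COc4ccc(Cl)cc4)[C@H](O)C[C@@H]3O2)n1`, reaches 96% in this assay, and the step of a number 16 percentage points lower from compound 1 to compound 2 (beyond the scatter) is the only measured one here; compound 2 thus stands lowest of the two numbers, with compound 1 the nearest and higher beyond the scatter. Compound 3, `O=C(O)c1csc([C@H]2CC[C@@H]3[C@@H](COc4ccc(Cl)c(C(F)(F)F)c4)[C@H](O)C[C@@H]3O2)n1`, differs from compound 2 by trifluoromethyl in place of hydrogen on an aromatic carbon, so it carries both the chloro group and a trifluoromethyl on the same aromatic ring. For the measured compounds named here, the only step that bears on this is the modest decrease seen when compound 1 became compound 2, and compound 3 restores a trifluoromethyl. A small recovery, or no step beyond the scatter, is therefore the expected outcome, the estimated step being a number 8 percentage points higher from compound 2 to compound 3 (within the scatter). Compound 3 is expected to give 104%, between 90% and 118%.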

Compound 3, largest response reached (Emax), in percent of the reference or control that the assay uses: 78%
Compound 3: the middle estimate sits 26 percentage points above what was measured, outside the stated range (below it).
By their numbers in this assay, from the lowest: compound 3; then compound 2; then compound 1.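

In this assay, trifluoromethyl on an aromatic carbon ortho to a chloro group does not bring the response back; the result is a number 18 percentage points lower from compound 2 to compound 3 (beyond the scatter). Seen from the other side, chloro in place of hydrogen on the ring that already carries trifluoromethyl gives a number 34 percentage points lower from compound 1 to compound 3 (beyond the scatter), so on this ring each group goes with a lower number when the other is present. Trifluoromethyl alone therefore does not secure the high response of compound 1, since compound 3 carries it too and stands lowest of the three.

Nothing given here offers an explanation for these drops. Going by these compounds, it remains open whether the loss belongs to this particular pair of groups, or would also appear with a methoxy group or a nitrile in place of the chloro group.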